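This account rests on a few compounds, and the source may have more. Where it says the series, first, only, none or still open, it means among the compounds named here.

Working notes on the series. The shared core carries a pyrrolidinylmethyl arm and a methyl on the core, with an aryl group varied across the set. Compound 1 `Cn1nc(CN2CCCC2)nc1-c1ccc2c(c1)CCCC2` gives 26 nM in an assay on membranes from Jurkat cells for displacement of a labelled ligand from Sigma non-opioid intracellular receptor 1 (Homo sapiens), read by scintillation counting, with a stated time of 2 h (on this read-out higher numbers stand for weaker inhibition and lower numbers for stronger inhibition), compound 3 `Cn1nc(CN2CCCC2)nc1-c1ccc(Cl)c(Cl)c1` gives 22 nM, and compound 2 `CC(C)c1ccc(-c2nc(CN3CCCC3)nn2C)cc1` gives 96 nM. Compound 2 thus stands at the highest number of the three; the gaps to compound 1 and to compound 3 both lie beyond the usual scatter, so on these numbers compound 2 is the weakest binder of the measured set.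

Compound 4 `Cn1nc(CN2CCCC2)nc1-c1ccc(C(C)(C)C)cc1` has not yet been measured. It differs from compound 2 in one place: methyl in place of hydrogen on a saturated chain carbon bound to an aromatic carbon and two saturated chain carbons. Within the data shown here, no step between two measured compounds isolates a change of this kind, so there is no direct precedent in the set for what it does.

The expectation for this assay is a small step from compound 2 toward a lower number, a 1.6-fold lower number from compound 2 to compound 4 (0.20 log units; within the scatter), which may not clear the scatter. Compound 4 is therefore estimated at 60 nM, with a range from 20 nM to 200 nM.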

Compound 4, inhibition constant: 7.5 nM
Compound 4: the middle estimate sits 8.0-fold (0.90 log units) above what was measured; the measured number lies below the stated range.
By their numbers in this assay, from the lowest: compound 4; then compounds 3 and 1 (each within the scatter of the next); then compound 2.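

In this assay, among these compounds, the isopropyl to tert-butyl change gives the first single-place step in the set, and it is large: a 13-fold lower number from compound 2 to compound 4 (1.11 log units; beyond the scatter), well beyond the scatter. At this saturated chain carbon bound to an aromatic carbon and two saturated chain carbons, then, one added methyl, with no ring, no hydrogen-bond donor or acceptor and no net charge, is enough to move the number substantially. No supporting data bear on why this single change has so large an effect.

Going by these compounds, whether the number keeps falling with a larger group at this place, such as a 1-methylcyclohexyl or a trimethylsilyl group, remains open, as does the outcome with a trifluoromethyl group in place of the added methyl. On these data alone, it is also open whether the same methyl gives a step of this size on another aryl group.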